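Shortening the acyl chain on a thioglycoside thiadiazole

The source may hold more compounds than are shown below. What is called first, only, known or untested is meant among the compounds shown, and "the series" means these compounds.

Measured so far:
- Compound 1 `CCCCCCCC/C=C\CCCCCCCC(=O)Nc1nnc(S[C@@H]2O[C@H](CO)[C@H](O)[C@H](O)[C@H]2O)s1` — in an ADME assay on CHO-K1 cells (Cricetulus griseus) for cytotoxicity, read by MTT assay, with a stated time of 24 h (on this read-out lower numbers stand for stronger inhibition and higher numbers for weaker inhibition), compound 1 is "not active" (no number reported)
- Compound 2 `CCCCCC(=O)Nc1nnc(S[C@@H]2O[C@H](COC(C)=O)[C@H](OC(C)=O)[C@H](OC(C)=O)[C@H]2OC(C)=O)s1` — in this assay compound 2 gives 24400 nM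

Compound 1 shows no number in this assay, only a report of no activity, while compound 2, with its acetylated sugar and shorter chain, gives a weak figure. Compound 3 `CCCCCCCCCCCC(=O)Nc1nnc(S[C@@H]2O[C@H](CO)[C@H](O)[C@H](O)[C@H]2O)s1` keeps the free sugar of compound 1 and changes the chain: butyl in place of dec-1-en-1-yl on a saturated chain carbon, seven bonds along the chain from a carbonyl carbon. Among the compounds with values here, with no measured step to lean on, compound 3 is expected to remain weak, estimated at 60000 nM within 15000 nM to 250000 nM.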

Compound 3, half-maximal inhibitory concentration: "not active" (no number reported)
Compound 3 has no reported number here; there is nothing to compare the estimate with.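

In this assay compound 1 and compound 3 both lack a number, so no step can be read between them, and no other data bear on this result. The compounds shown leave open how far swapping dec-1-en-1-yl for butyl shifts cytotoxicity.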